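Chain length step in a dual hydroxycarbamoyl series

This account rests on a few compounds, and the source may have more. Where it says the series, first, only, none or still open, it means among the compounds named here.

Measured so far:
compound 1, `CC(C)CCc1c(OCCCCCC(=O)NO)ccc(CCC(=O)NO)c1O`: 5410 nM
compound 2, `CC(C)CCc1c(OCCCCCCCC(=O)NO)ccc2ccc(=O)oc12`: 2190 nM

Going by the values given here, in a functional assay on A549 cells (Homo sapiens) for antiproliferative activity, read by sulforhodamine B assay, with a stated time of 48 h (a higher number here means a weaker inhibitor of growth, a lower number a stronger inhibitor of growth), compound 1 gives 5410 nM and stands highest of the two numbers so far; compound 2 sits at 2190 nM, a gap beyond the scatter. The two differ in several places at once, so no single step can be read from them.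

Compound 3, `CC(C)CCc1c(OCCCCC(=O)NO)ccc(CCC(=O)NO)c1O`, is the next point and keeps the core of compound 1 intact. The change is hydroxycarbamoyl in place of (hydroxycarbamoyl)methyl on a saturated chain carbon, four bonds along the chain from an oxygen on an aromatic ring. It removes one chain carbon from the alkoxy-linked arm and nothing else.

Among the compounds with values here, with no step between measured compounds in hand, the expectation for this change in this assay is a small shift, if any, not beyond the scatter, in either direction. Compound 3 is therefore estimated at 5000 nM (range 2500 nM to 10000 nM). This estimate means a step of a 1.1-fold lower number from compound 1 to compound 3 (0.03 log units; within the scatter), essentially flat.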

Compound 3, concentration for 50% growth inhibition: 10000 nM
For compound 3 the middle estimate is 2.0-fold (0.30 log units) below the measured one; the measured number falls inside the stated range.
By their numbers in this assay, from the lowest: compound 2; then compounds 1 and 3 (each within the scatter of the next).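

In this assay, the change to hydroxycarbamoyl in place of (hydroxycarbamoyl)methyl gives a 1.8-fold higher number from compound 1 to compound 3 (0.27 log units; within the scatter) on the same core. Going by these compounds alone, this is the first single-place step, and it shows that removing one chain carbon from the alkoxy-linked arm, on a saturated chain carbon four bonds along the chain from an oxygen on an aromatic ring, does not carry the number past the scatter. One step gives no trend along the chain.

Still open, as far as these compounds go, is whether a longer chain on this arm, or a carboxylic acid in place of the hydroxycarbamoyl end, would move the number beyond the scatter. Within the data shown here, the second hydroxycarbamoyl arm stays fixed in both compounds, so the same shortening there has no step to read. No supporting measurement bears on this step.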